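The source may report more compounds than this note shows. Statements on the series, on what has been measured and on what is new or still open speak of the compounds shown alone.

Compound 1 `O=C(c1ccccc1F)N1CC(c2nc(-c3cccc(Cl)c3)no2)C1` and compound 2 `O=C(C1CCC2(CCC2)CC1)N1CC(c2nc(-c3cccc(Cl)c3)no2)C1` share one core and differ only at the carbonyl carbon. In an assay on HEK293 cells for negative allosteric modulation of metabotropic glutamate receptor 5 (Homo sapiens), read by FLIPR (on this read-out lower numbers stand for stronger inhibition and higher numbers for weaker inhibition), compound 1 gives 670 nM. For compound 2 this assay reports only a limit, > 10000 nM, so compound 2 stands at the edge of what the read-out resolves (the limit of > 10000 nM in this assay, at which 1 of the 2 values shown sits). For the measured compounds named here, the single measured step, an at least 14-fold higher number from compound 1 to compound 2 (1.17 log units; beyond the scatter), is the only guide available. Compound 3 `COC1CCCN(C(=O)N2CC(c3nc(-c4cccc(Cl)c4)no3)C2)C1` differs from compound 2 by a group of 8 heavy atoms (6 carbon, 1 nitrogen, 1 oxygen; one six-membered non-aromatic ring with 1 hetero atom) in place of a group of 9 heavy atoms (9 carbon; one four-membered non-aromatic ring of carbon only, one six-membered non-aromatic ring of carbon only), on a carbonyl carbon, on a carbonyl carbon whose other neighbour is an amide-type nitrogen in a ring. That one step bears on it only loosely: replacing the aromatic ring with rings of carbon only cost a large amount, and compound 3 exchanges those rings for a six-membered non-aromatic ring with 1 hetero atom, not for the aromatic ring. The expected step in this assay is an at least 2.0-fold lower number from compound 2 to compound 3 (0.30 log units; that floor lies within the scatter), though a limit at the start leaves its real size uncertain. Compound 3 is expected to give 5000 nM, in the range 1500 nM to 20000 nM.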

Compound 3, half-maximal inhibitory concentration: 1830 nM
Compound 3: middle estimate off by 2.7-fold (0.44 log units), on the high side; the measured number falls inside the stated range.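

In this assay, a non-aromatic ring on the carbonyl carbon does not by itself carry the whole loss: with 3-methoxypiperidin-1-yl in place of the carbon-only rings, the data give an at least 5.4-fold lower number from compound 2 to compound 3 (0.73 log units; beyond the scatter). The 2-fluorophenyl group still keeps an edge over 3-methoxypiperidin-1-yl, with a 2.7-fold higher number from compound 1 to compound 3 (0.44 log units; beyond the scatter). The value of compound 2 is a limit, and the step out of it gives only a floor on the size of the change: the limit of > 10000 nM in this assay, at which 1 of the 3 values shown sits.

As far as these compounds go, whether the recovery follows the methoxy group or the piperidine ring stays open, and plain piperidin-1-yl or morpholin-4-yl on the same carbonyl carbon would separate the two. From the compounds shown here alone, the part played by the fluorine of the 2-fluorophenyl group is also open, and unsubstituted phenyl there would address it.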